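The source may hold more compounds than are shown below. What is called first, only, known or untested is meant among the compounds shown, and "the series" means these compounds.

Compound 1, `c1ccc2c(c1)CCC2CCCN1CCN(c2cccc3c2OCCO3)CC1`, in a functional assay on the whole organism for antagonist activity, with Rattus norvegicus as the target (on this read-out higher numbers stand for an effect only at larger amounts of compound and lower numbers for an effect already at smaller amounts), gives 0.16 mg/kg.
Compound 2, `c1ccc2c(c1)CC2CCCN1CCN(c2cccc3c2OCCO3)CC1`, in this assay gives 0.16 mg/kg.
Compound 3, `Clc1cccc2c1CC2CCCN1CCN(c2cccc3c2OCCO3)CC1`, in this assay gives 0.63 mg/kg.

Compound 2 stands level with compound 1 at the digits shown, and the two share the lowest number of the three; its step to compound 3 is a 3.9-fold higher number from compound 2 to compound 3 (0.60 log units; beyond the scatter), a chloro in place of hydrogen on an aromatic carbon.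

Compound 4, `c1ccc2c(c1)CC(CCN1CCN(c3cccc4c3OCCO4)CC1)C2`, has not yet been measured. It is built from the same atoms as compound 2, joined differently: a group of 9 heavy atoms (9 carbon; one five-membered non-aromatic ring of carbon only, one six-membered aromatic ring of carbon only) in place of a group of 9 heavy atoms (9 carbon; one four-membered non-aromatic ring of carbon only, one six-membered aromatic ring of carbon only), on a saturated chain carbon, two bonds along the chain from an amine nitrogen in a ring.

Going by the values given here, the one measured step that bears on this is no change at the digits printed from compound 1 to compound 2 (within the scatter), where a five-membered non-aromatic ring gave way to a four-membered one without any change beyond the scatter. The return to a five-membered ring in compound 4 therefore carries no sign of a shift on its own. Among the compounds with values here, the change in the place of attachment along the chain, however, has no measured counterpart here, so some uncertainty remains. On balance, a step of about a 1.6-fold higher number from compound 2 to compound 4 (0.19 log units; within the scatter) is expected, lying within the scatter. For compound 4 the estimated value in this assay is 0.25 mg/kg, with a range from 0.08 mg/kg to 0.8 mg/kg.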

Compound 4, minimum effective dose: 0.16 mg/kg
Compound 4: the middle estimate sits 1.6-fold (0.19 log units) above what was measured; the range from low to high includes it.
By their numbers in this assay, from the lowest: compounds 1, 2 and 4 (each within the scatter of the next); then compound 3.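

In this assay, putting 2,3-dihydro-1H-inden-2-yl on a saturated chain carbon, two bonds along the chain from an amine nitrogen in a ring, gives no change at the digits printed from compound 2 to compound 4 (within the scatter). Going by these compounds alone, the earlier steps changed only the group three bonds along the chain, so this is the first sign that the same atoms can be joined at a different place on the chain without a change beyond the scatter, although it rests on this single pair. No measurement here explains why the number holds steady.

As far as these compounds go, it remains open whether a chloro on an aromatic carbon of the 2,3-dihydro-1H-inden-2-yl group would raise the number as it did in a 3.9-fold higher number from compound 2 to compound 3 (0.60 log units; beyond the scatter). From the compounds shown here alone, a fluoro at that kind of carbon, or a longer chain carrying the same group, also remains untested in these compounds.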